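Sulfur Replaced by Selenium: Expected Shift in Growth Inhibition

The compounds below may be only part of what the source reports. "The series", "measured", "known", "first", "only" and "open" are said of these compounds alone.

Three compounds have been measured in a functional assay on HepG2 cells (Homo sapiens) for cytotoxicity, read by MTT assay, with a stated time of 72 h; on this read-out higher numbers stand for weaker inhibition of growth and lower numbers for stronger inhibition of growth:
Compound 1, `CS/C(=N\C(=O)c1sccc1Cl)NC(=O)c1sccc1Cl`, compound 1 gives 65300 nM.
Compound 2, `CS/C(=N\C(=O)c1csc([N+](=O)[O-])c1)NC(=O)c1csc([N+](=O)[O-])c1`, compound 2 gives 63400 nM.
Compound 3, `C[Se]/C(=N\C(=O)c1cnc2ccccc2c1)NC(=O)c1cnc2ccccc2c1`, compound 3 gives 4160 nM.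

Compound 2 sits close to compound 1, within the usual scatter of this assay, and far above compound 3, beyond the scatter. Compound 4, `C[Se]/C(=N\C(=O)c1csc([N+](=O)[O-])c1)NC(=O)c1csc([N+](=O)[O-])c1`, is compound 2 with one change: a group of 2 heavy atoms (1 carbon, 1 selenium; no ring) in place of a group of 2 heavy atoms (1 carbon, 1 sulfur; no ring), on a carbon with a double bond to nitrogen. Among the compounds with values here, compound 3 carries the same selenium-bearing group but on a different aromatic part, so no single measured step isolates this swap. Still, the low value of compound 3 suggests stronger growth inhibition is plausible. The step from compound 2 to compound 4 is expected to be a 2.5-fold lower number from compound 2 to compound 4 (0.40 log units; beyond the scatter). Compound 4 is estimated at 25000 nM, within 6000 nM to 90000 nM.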

Compound 4, concentration for 50% growth inhibition: 620 nM
Estimate against measurement, compound 4: 40-fold (1.61 log units) above; measured number outside the range, below it.
By their numbers in this assay, from the lowest: compound 4; then compound 3; then compounds 2 and 1 (each within the scatter of the next).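

In this assay replacing methylsulfanyl with its selenium counterpart, on the carbon with a double bond to nitrogen, gives a 100-fold lower number from compound 2 to compound 4 (2.01 log units; beyond the scatter) with the rest of the molecule unchanged. Within the data shown here, this is the first direct reading of the swap, and it shows that exchanging sulfur for selenium at this place is enough on its own to produce a large step. Nothing available explains the size of that step.

Going by these compounds, whether the swap gives a step of similar size on other aromatic parts remains open. So does the outcome with a longer chain on selenium, such as ethyl, or with an amine at this place.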